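Isopropylsulfanyl for methylsulfanyl at a cytotoxicity limit

The source may report more compounds than this note shows. Statements on the series, on what has been measured and on what is new or still open speak of the compounds shown alone.

In an ADME assay on MOLT-3 cells (Homo sapiens) for cytotoxicity, with a stated time of 7 days (on this read-out lower numbers stand for higher toxicity in this test and higher numbers for lower toxicity in this test), compound 1 (`Nc1nc(OCC(F)(F)F)c2ncn(/C=C3/CC3(CO)CO)c2n1`) gives > 20000 nM as a limit. Compound 2 (`CSc1nc(N)nc2c1ncn2/C=C1/CC1(CO)CO`) gives > 20000 nM as a limit too, so it has no exact number. Compound 3 (`CC(C)Sc1nc(N)nc2c1ncn2/C=C1/CC1(CO)CO`) carries isopropyl in place of methyl on a sulfur. Among the measured compounds shown here, the one measured step bearing on this is a step that the two limits leave unreadable from compound 1 to compound 2 and it gives no size. The evidence is the limit of > 20000 nM in this assay, at which 2 of the 2 values shown sit, alone. No step beyond the scatter is therefore expected in this assay and the estimated step is a step that the limit leaves unreadable from compound 2 to compound 3 in all. Compound 3 is estimated at 22000 nM with 10000 nM to 50000 nM as its expected range.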

Compound 3, half-maximal cytotoxic concentration: > 20000 nM
Compound 3: only a limit was reported (the forecaster's own chance of this, stated with the estimate: 85%); the middle value is on the limit's open side.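

Among the compounds shown here, compound 1, compound 2 and compound 3 each give only a limit in this assay, so no step between them can be read. The compounds shown leave open where the true cytotoxic concentration of each lies beyond that limit.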